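From 4-Methylphenyl to 2,3-Dihydroxyphenyl on a Benzyl Arm

This account rests on a few compounds, and the source may have more. Where it says the series, first, only, none or still open, it means among the compounds named here.

Three measured compounds share one core and differ only in the aromatic ring carried on a saturated chain carbon bound to a nitrogen on an aromatic ring. Compound 1 is `OC[C@H]1O[C@@H](n2cnc3c(NCc4ccccc4Cl)ncnc32)[C@H](O)[C@@H]1O`. In a functional assay on MCF cells (Homo sapiens) for antiproliferative activity, with a stated time of 72 h (on this read-out lower numbers stand for stronger inhibition and higher numbers for weaker inhibition), compound 1 gives > 166000 nM, which is a limit of the assay and not a number. Compound 2 is `Cc1cccc(CNc2ncnc3c2ncn3[C@@H]2O[C@H](CO)[C@@H](O)[C@H]2O)c1`; in this assay compound 2 gives > 166000 nM, again only a limit. Compound 3 is `Cc1ccc(CNc2ncnc3c2ncn3[C@@H]2O[C@H](CO)[C@@H](O)[C@H]2O)cc1`; in this assay compound 3 gives > 166000 nM, once more a limit. Because every value sits at the limit of > 166000 nM in this assay, at which 3 of the 3 values shown sit, the three steps between them, a step that the two limits leave unreadable from compound 1 to compound 2, a step that the two limits leave unreadable from compound 1 to compound 3 and a step that the two limits leave unreadable from compound 2 to compound 3, have no readable size, and compound 3 cannot be placed above or below its two neighbours.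

Compound 4 is `OC[C@H]1O[C@@H](n2cnc3c(NCc4cccc(O)c4O)ncnc32)[C@H](O)[C@@H]1O`. It differs from compound 3 by 2,3-dihydroxyphenyl in place of 4-methylphenyl on a saturated chain carbon bound to a nitrogen on an aromatic ring. Among the measured compounds shown here, none of the measured steps bears on this change, and none of them yields a size at all, so no direction can be drawn from them. The plain expectation is that compound 4 stays near the limit, with a real chance that a number appears. Compound 4 is therefore estimated at 150000 nM, within 30000 nM to 500000 nM, an expected step of an at least 1.1-fold lower number from compound 3 to compound 4 (0.04 log units; that floor lies within the scatter).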

Compound 4, half-maximal inhibitory concentration: 5200 nM
Compound 4: middle estimate off by 29-fold (1.46 log units), on the high side, and the stated range ends above it.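

In this assay, among the compounds shown here, this position proves able to move the read-out, something the earlier compounds could not show: with 2,3-dihydroxyphenyl on the benzyl arm, the series gives its first real number. The change brings an at least 31-fold lower number from compound 3 to compound 4 (1.50 log units; beyond the scatter), an at least 31-fold lower number from compound 2 to compound 4 (1.50 log units; beyond the scatter) and an at least 31-fold lower number from compound 1 to compound 4 (1.50 log units; beyond the scatter), so a swap of the aromatic ring alone, with the shared core untouched, is enough to produce a large change. These three sizes are floors and not exact gaps, and the steps among compounds 1, 2 and 3 cannot be read, because the earlier compounds give only a limit and no number: the limit of > 166000 nM in this assay, at which 3 of the 4 values shown sit.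

The compounds shown leave open which part of the change matters, since compound 4 gains two hydroxyl groups and loses the methyl group of compound 3 in a single step, so 2-hydroxyphenyl or 3-hydroxyphenyl alone could give a number or could stay at the limit. They also leave open whether 2,3-dimethoxyphenyl, with methyl groups capping both oxygens, or an amine or a carboxylic acid on the ring in place of the hydroxyl groups would give a number in this assay.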